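Replacing 4-methylphenyl with 3-chloropropyl in compound 3

The source may report more compounds than this note shows. Statements on the series, on what has been measured and on what is new or still open speak of the compounds shown alone.

In a functional assay on CFPAC-1 cells (Homo sapiens) for antiproliferative activity, read by MTT assay, with a stated time of 72 h (on this read-out higher numbers stand for weaker inhibition and lower numbers for stronger inhibition), compound 1 (`O=C1O[C@H]([C@@H](O)Cn2cc(-c3ccc(Br)cc3)nn2)C(OCc2ccccc2)=C1OCc1ccccc1`) gives 5830 nM. Compound 2 (`COc1ccccc1-c1cn(C[C@H](O)[C@H]2OC(=O)C(OCc3ccccc3)=C2OCc2ccccc2)nn1`) reads > 100000 nM, which is a limit. Compound 3 (`Cc1ccc(-c2cn(C[C@H](O)[C@H]3OC(=O)C(OCc4ccccc4)=C3OCc3ccccc3)nn2)cc1`) also reads > 100000 nM, again only a limit. Compound 4 (`O=C1O[C@H]([C@@H](O)Cn2cc(CCCCl)nn2)C(OCc2ccccc2)=C1OCc1ccccc1`) has 3-chloropropyl in place of 4-methylphenyl on an aromatic carbon of a five-membered aromatic ring with 3 nitrogen: 3-chloropropyl in place of 4-methylphenyl on an aromatic carbon. The measured changes at this carbon are both large: an at least 17-fold higher number from compound 1 to compound 2 (1.23 log units; beyond the scatter) and an at least 17-fold higher number from compound 1 to compound 3 (1.23 log units; beyond the scatter). Neither involves a chain, so they bear on compound 4 only loosely. Compound 4 keeps a halogen, as does compound 1 at 5830 nM, so a modest shift towards stronger inhibition is expected. Another limit is equally likely for compound 4. The expected step is an at least 2.5-fold lower number from compound 3 to compound 4 (0.39 log units; beyond the scatter). For compound 4 the estimated value is 40000 nM, within 8000 nM to 100000 nM.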

Compound 4, half-maximal inhibitory concentration: 58800 nM
Compound 4: the middle estimate sits 1.5-fold (0.17 log units) below what was measured, and the stated range covers the measured number.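

In this assay, a ring at this aromatic carbon is not needed for a measured number: 3-chloropropyl gives one, where 4-methylphenyl and 2-methoxyphenyl give only limits (an at least 1.7-fold lower number from compound 3 to compound 4 (0.23 log units; that floor lies within the scatter); an at least 1.7-fold lower number from compound 2 to compound 4 (0.23 log units; that floor lies within the scatter)). Both steps give only a floor, not a size: the limit of > 100000 nM in this assay, at which 2 of the 4 values shown sit. The chain does not match 4-bromophenyl (a 10-fold higher number from compound 1 to compound 4 (1.00 log units; beyond the scatter)).

Whether the chlorine itself matters stays open, since a plain propyl chain is not among the compounds shown. Also open, as far as these compounds go, is whether a longer chain or a terminal amine at this carbon would read closer to compound 1.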